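The source may hold more compounds than are shown below. What is called first, only, known or untested is meant among the compounds shown, and "the series" means these compounds.

Measured compounds:
- compound 1, `N#Cc1cc[n+]([O-])cc1Oc1ccccc1`: 300 mg/kg
- compound 2, `COc1ccc(Oc2c[n+]([O-])ccc2C)cc1`: 300 mg/kg
- compound 3, `[O-][n+]1ccc(CO)c(Oc2ccccc2)c1`: 300 mg/kg

All three were tested in a functional assay on the whole organism with Mus musculus as the target, in the maximal electroshock model, with a stated time of 30 min; on this read-out lower numbers stand for an effect already at smaller amounts and higher numbers for an effect only at larger amounts of compound. Compound 3, with the structure `[O-][n+]1ccc(CO)c(Oc2ccccc2)c1`, stands level with compound 1 and compound 2 at the digits shown; the step of no change at the digits printed from compound 1 to compound 3 (within the scatter) lies within the scatter, and the gap to compound 2 is also within the scatter, so none of the three can be called the strongest or the weakest.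

Compound 4, `CC(C)c1cc[n+]([O-])cc1Oc1ccccc1`, has not yet been measured. It differs from compound 3 in one place: isopropyl in place of hydroxymethyl on an aromatic carbon.

For the measured compounds named here, only one measured step bears on this change, the one from compound 1 to compound 3, where a different group was swapped at the same aromatic carbon, and that step, no change at the digits printed from compound 1 to compound 3 (within the scatter), showed no change beyond the scatter. Going by the values given here, no compound carrying an isopropyl at that carbon has been measured, so the evidence for this particular swap is indirect. Because the step of no change at the digits printed from compound 1 to compound 3 (within the scatter) showed no change, compound 4 is expected to give 300 mg/kg, within a range of 150 mg/kg to 600 mg/kg. The expected step is no change at the digits printed from compound 3 to compound 4 (within the scatter), that is, no change beyond the scatter.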

Compound 4, minimum effective dose: 30 mg/kg
Estimate against measurement, compound 4: 10-fold (1.00 log units) above; the whole stated range lies above it.
By their numbers in this assay, from the lowest: compound 4; then compounds 1, 2 and 3 (each within the scatter of the next).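

At the aromatic carbon opposite the ring nitrogen, the group can clearly matter in this assay: replacing cyano with hydroxymethyl had shown no change beyond the scatter, but isopropyl gives a 10-fold lower number from compound 3 to compound 4 (1.00 log units; beyond the scatter) and, measured against the cyano compound, a 10-fold lower number from compound 1 to compound 4 (1.00 log units; beyond the scatter). Compared with the hydroxymethyl it replaces, isopropyl has 3 heavy atoms rather than 2 and 0 hydrogen-bond donors rather than 1, so this single swap changes several counted features at once. No measurement available here explains why the number falls.

As far as these compounds go, it remains open whether this result is specific to isopropyl or extends to other groups at the same carbon, such as ethyl, tert-butyl or an amine, which would help show which of those differences goes with the lower number. From the compounds shown here alone, it is also open whether isopropyl would give a similar step if the rest of the core were changed, for example with the methoxy group carried by compound 2.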